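A Methyl Group on the Amide Phenyl Ring

A few compounds are considered here, and "the series" means these few. Any claim that something is new, unique, unknown or untested is made for them only; others in the source may bear on it.

Compound 1, `C=CC1=C(C(=O)NCC(C)C)C(c2ccc(F)cc2)OC1`: > 100000 nM in a functional assay on QGY7701 cells (Homo sapiens) for cytotoxicity, read by MTT assay, with a stated time of 24 h (on this read-out higher numbers stand for weaker inhibition and lower numbers for stronger inhibition), which is a limit of the assay and not a number.
Compound 2, `C=CC1=C(C(=O)Nc2ccccc2)C(c2ccc(F)cc2)OC1`: 46700 nM in this assay.

Going by the values given here, compound 2 carries the only numeric value shown in this assay; the other entry is the limit of > 100000 nM in this assay, at which 1 of the 2 values shown sits. Among the compounds with values here, the one measured step, an at least 2.1-fold lower number from compound 1 to compound 2 (0.33 log units; beyond the scatter), is therefore known only as a lower bound on its size.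

Compound 3 is `C=CC1=C(C(=O)Nc2cccc(C)c2)C(c2ccc(F)cc2)OC1`. Relative to compound 2 it differs by methyl in place of hydrogen on an aromatic carbon. No measured step concerns a substituent on the phenyl ring of the amide; the only step recorded, from compound 1 to compound 2, exchanges the whole group on the amide nitrogen and bears on the present change only indirectly, by showing that the phenyl amide is the more potent of the two shown.

Within the data shown here, with no closer precedent, the expectation for compound 3 is a step of a 1.3-fold lower number from compound 2 to compound 3 (0.13 log units; within the scatter) that stays within the usual scatter. Compound 3 is therefore estimated at 35000 nM in this assay, with a range from 12000 nM to 90000 nM.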

Compound 3, half-maximal inhibitory concentration: 56400 nM
Compound 3: the middle estimate sits 1.6-fold (0.21 log units) below what was measured; measured number inside the range.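

The first substituent on the phenyl ring of the amide makes no difference that can be read in this assay: the step is a 1.2-fold higher number from compound 2 to compound 3 (0.08 log units; within the scatter), so with a methyl at this place, meta to a large group, compound 2 and compound 3 cannot be told apart. The comparison with the isobutyl amide is weaker for the new compound, since the step is an at least 1.7-fold lower number from compound 1 to compound 3 (0.24 log units; that floor lies within the scatter), and a floor of that size does not separate the 3-methylphenyl group from the isobutyl group. Compound 1 remains a limit of the assay and not a number, and this floor rests on it: the limit of > 100000 nM in this assay, at which 1 of the 3 values shown sits.

On these data alone, one methyl group at one place on the ring says little about the ring as a whole, so it remains open whether a chlorine atom, a methoxy group or an amine there would give a number beyond the scatter from compound 2. Also open, as far as these compounds go, is whether the same methyl group elsewhere on the ring, or a longer chain on the amide nitrogen, would shift the read-out.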